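Amide aryl swap in a piperidine dopamine receptor series

This account rests on a few compounds, and the source may have more. Where it says the series, first, only, none or still open, it means among the compounds named here.

Measured compounds:
compound 1 `Cc1cc(C)cc(NC(=O)CN2CCC(c3cccc[n+]3[O-])CC2)c1` — 76%
compound 2 `Cc1cccc(C(=O)NCN2CCC(c3cccc[n+]3[O-])CC2)c1` — 77%
compound 3 `Cc1cccc(NC(=O)CN2CCC(c3ccc(O)cn3)CC2)c1` — 83%

In a functional assay on HEK293 cells for agonist activity at D(4) dopamine receptor (Homo sapiens), read by FLIPR (on this read-out lower numbers stand for smaller maximal responses and higher numbers for larger maximal responses), compound 1 gives 76%, the lowest of the three numbers, yet compound 2 with 77% and compound 3 with 83% both sit within the scatter of it, so no order among the three is supported. Compound 4 `O=C(CN1CCC(c2cccc[n+]2[O-])CC1)Nc1ccccc1F` differs from compound 1 by 2-fluorophenyl in place of 3,5-dimethylphenyl on an amide-type nitrogen. For the measured compounds named here, no measured pair in this set shows what such a change does to the maximal response, so no step beyond the scatter is expected in either direction. Compound 4 is therefore estimated at 73%, with a range from 58% to 88%. The implied step a number 3 percentage points lower from compound 1 to compound 4 (within the scatter) is expected to stay inside the scatter.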

Compound 4, largest response reached (reported as efficacy), in percent of the reference or control that the assay uses: 63%
Beside the measured number, compound 4's estimate is 10 percentage points above it; the measured number falls inside the stated range.
By their numbers in this assay, from the lowest: compound 4; then compounds 1, 2 and 3 (each within the scatter of the next).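

In this assay, the aryl group on the amide-type nitrogen now gives the series its first step beyond the scatter: 2-fluorophenyl in place of 3,5-dimethylphenyl gives a number 13 percentage points lower from compound 1 to compound 4 (beyond the scatter) as a modest change. The maximal response therefore depends on the group at this position, while compound 4 still reaches 63% in that read-out. No measurement at hand accounts for this step.

The swap removes both methyl groups and adds fluorine in a single change, so this pair cannot show which part carries the step. As far as these compounds go, whether unsubstituted phenyl on the same nitrogen would align with compound 1 or compound 4 remains open.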